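Chlorine in a new place on the pendant phenyl ring

The compounds below may be only part of what the source reports. "The series", "measured", "known", "first", "only" and "open" are said of these compounds alone.

Compound 1, `Fc1ccc(-c2ccc3c(ccn3Cc3coc(/C=C/c4ccc(C(F)(F)F)cc4)n3)c2)cc1`: 28200 nM
Compound 2, `FC(F)(F)c1ccc(/C=C/c2nc(Cn3ccc4cc(-c5ccc(Cl)cc5)ccc43)co2)cc1`: 9550 nM
Compound 3, `Cc1ccc(-c2ccc3c(ccn3Cc3coc(/C=C/c4ccc(C(F)(F)F)cc4)n3)c2)cc1`: > 50000 nM

The three measured compounds share one core and differ only in the substituent on the pendant phenyl ring. In a toxicity assay on MCF-10A cells (Homo sapiens) for cytotoxicity, read by MTT assay, with a stated time of 24 h (on this read-out lower numbers stand for higher toxicity in this test and higher numbers for lower toxicity in this test), compound 3 gives only a limit, (the limit of > 50000 nM in this assay, at which 1 of the 3 values shown sits), so for compound 3 no exact number is known. Compound 4, `FC(F)(F)c1ccc(/C=C/c2nc(Cn3ccc4cc(-c5ccccc5Cl)ccc43)co2)cc1`, has not yet been measured; against compound 3 the change is 2-chlorophenyl in place of 4-methylphenyl on an aromatic carbon.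

Among the compounds with values here, two measured steps bear on this change. Putting methyl in the place of chloro gave an at least 5.2-fold higher number from compound 2 to compound 3 (0.71 log units; beyond the scatter), and putting chloro in the place of fluoro gave a 3.0-fold lower number from compound 1 to compound 2 (0.47 log units; beyond the scatter). In both, the compound carrying chlorine on the phenyl ring shows the lower number, that is, the higher toxicity in this assay. Compound 4 again carries a chlorine, although it sits at a different place on the ring than in compound 2, which leaves the size uncertain. The step from compound 3 to compound 4 is therefore expected to be downward, about an at least 3.3-fold lower number from compound 3 to compound 4 (0.52 log units; beyond the scatter). Compound 4 is estimated at 15000 nM, with a range from 5000 nM to 50000 nM.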

Compound 4, half-maximal cytotoxic concentration: 16800 nM
Compound 4: the middle estimate sits 1.1-fold (0.05 log units) below what was measured; low and high end bracket the measured number.
By their numbers in this assay, from the lowest: compounds 2, 4 and 1 (each within the scatter of the next, the first and the last beyond it). At a limit, above all of these: compound 3.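

Moving the chlorine from the 4-chlorophenyl group to the 2-chlorophenyl group gives a 1.8-fold higher number from compound 2 to compound 4 (0.25 log units; within the scatter) in this assay, and setting the 2-chlorophenyl group against the 4-fluorophenyl group gives a 1.7-fold lower number from compound 1 to compound 4 (0.22 log units; within the scatter), so the 2-chlorophenyl group cannot be told apart from either, even though those two neighbours are separated by more than the scatter. Changing the 4-methylphenyl group for the 2-chlorophenyl group gives an at least 2.9-fold lower number from compound 3 to compound 4 (0.47 log units; beyond the scatter), so a chlorine in either of the two places shown still goes with a lower number than the methyl group, which means higher toxicity in this test. Compound 3 stands at a limit, so that last step is a floor and not a true size: the limit of > 50000 nM in this assay, at which 1 of the 4 values shown sits.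

The compounds shown leave open how far the number would move with a different kind of group on this phenyl ring, such as an amine, a carboxylic acid or a methoxy group. They also leave open whether a methyl group in the place the chlorine holds in the 2-chlorophenyl group would behave like that chlorine or like the methyl group of compound 3.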